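The source may report more compounds than this note shows. Statements on the series, on what has been measured and on what is new or still open speak of the compounds shown alone.

Measured so far:
- compound 1, `CC1(C)CNC(=O)c2sc(Nc3ccc(I)cc3Cl)c(C(=O)NCC[C@@H](O)CO)c2C1`: 12100 nM
- compound 2, `CC1(C)CNC(=O)c2sc(Nc3ccc(I)cc3F)c(C(=O)N[C@@H]3CCNC3)c2C1`: 54 nM
- compound 3, `CC1(C)CNC(=O)c2sc(Nc3ccc(I)cc3Cl)c(C(=O)NOC[C@H](O)CO)c2C1`: 896 nM

All three were run in a functional assay on HT-29 cells (Homo sapiens) for antiproliferative activity; a higher number here means a weaker inhibitor, a lower number a stronger inhibitor. On these three numbers compound 3 stands second highest: its nearest neighbour is compound 1, a higher number, and its furthest is compound 2, a lower number. Compound 2 differs from compound 3 in two places at once, so its value is noted only as a number and not as a step.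

The next compound, compound 4, `CC1(C)CNC(=O)c2sc(Nc3ccc(I)cc3Cl)c(C(N)=O)c2C1`, differs from compound 3 in one place: hydrogen in place of 2,3-dihydroxypropoxy on an amide-type nitrogen.

Among the measured compounds shown here, the only measured step that touches this place is a 14-fold lower number from compound 1 to compound 3 (1.13 log units; beyond the scatter), which swaps one chain for another on the same amide-type nitrogen and shows the substituent there to matter well beyond the scatter. For the measured compounds named here, no measured pair shows what removal of the whole chain does. The step is therefore expected to be real but its direction is uncertain; a moderate move is anticipated, with a lean toward a lower number, a 2.2-fold lower number from compound 3 to compound 4 (0.35 log units; beyond the scatter), and the range is kept wide on both sides.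

Compound 4 is expected at 400 nM, between 80 nM and 2500 nM.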

Compound 4, half-maximal inhibitory concentration: 596 nM
Compound 4: the middle estimate sits 1.5-fold (0.17 log units) below what was measured, and the stated range covers the measured number.
By their numbers in this assay, from the lowest: compound 2; then compounds 4 and 3 (each within the scatter of the next); then compound 1.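

Notes on the amide-type nitrogen: in this assay the 2,3-dihydroxypropoxy chain and hydrogen cannot be told apart at this place, with a 1.5-fold lower number from compound 3 to compound 4 (0.18 log units; within the scatter). The 3,4-dihydroxybutyl chain, by contrast, separates clearly from hydrogen, with a 20-fold lower number from compound 1 to compound 4 (1.31 log units; beyond the scatter), so a chain on this nitrogen does not carry a penalty as such: compound 3 carries one and still sits with the plain carbamoyl of compound 4, while compound 1 alone goes against that reading. Nothing on hand accounts for the gap between the two chains.

On these data alone, compound 2, at 54 nM, differs from each of the others in two places, so its steps cannot be read, and how much of its value belongs to the group on this nitrogen stays open. Also open, as far as these compounds go, is whether a plain ethyl or propyl chain, a 2-aminoethyl chain or a chain ending in a carboxylic acid on this nitrogen would fall with compound 1 or with compound 3 and compound 4.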